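Methanesulfonamido for acetamidomethyl: compound 1 to compound 3

This account rests on a few compounds, and the source may have more. Where it says the series, first, only, none or still open, it means among the compounds named here.

Two compounds of the series have numbers in a functional assay on blood for antagonist activity at thromboxane A2 receptor (Homo sapiens); a higher number here means weaker binding, a lower number tighter binding. Compound 1 `CC(=O)NCc1ccccc1-c1ccc(COC2CC[C@H](N3CCCCCC3)[C@H]2OC/C=C\CCC(=O)O)cc1` gives 25.1 nM in this assay. Compound 2 `O=C(O)CC/C=C\CO[C@@H]1[C@@H](OCc2ccc(-c3ccccc3)cc2)CC[C@@H]1N1CCCCC1` gives 100 nM in this assay. Within the data shown here, compound 1 therefore stands at the lower of the two numbers, and its gap to compound 2 lies beyond the scatter; the two differ in more than one place, so no single step between them can be read off.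

Compound 3 `CS(=O)(=O)Nc1ccccc1-c1ccc(COC2CC[C@H](N3CCCCCC3)[C@H]2OC/C=C\CCC(=O)O)cc1` has not been measured. It differs from compound 1 in one place: methanesulfonamido in place of acetamidomethyl on an aromatic carbon The group sits on an aromatic carbon of a six-membered aromatic ring of carbon only, ortho to a large group; cut one bond further out, the change reads 2-(acetamidomethyl)phenyl to 2-(methanesulfonamido)phenyl. Each group keeps one hydrogen-bond donor, while the entering group counts two acceptors against one.

Among the measured compounds shown here, no measured pair isolates this change, so the expectation rests on compound 1 alone. For compound 3 a small step is expected, a 1.6-fold lower number from compound 1 to compound 3 (0.20 log units; within the scatter), leaning toward a lower number, though a result within the scatter would not surprise. Compound 3 is estimated at 16 nM in this assay, between 5 nM and 60 nM.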

Compound 3, dissociation constant: 10 nM
Estimate against measurement, compound 3: 1.6-fold (0.20 log units) above; the measured number falls inside the stated range.
By their numbers in this assay, from the lowest: compound 3; then compound 1; then compound 2.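

Working note on this assay: methanesulfonamido in place of acetamidomethyl on the aromatic carbon gives a 2.5-fold lower number from compound 1 to compound 3 (0.40 log units; beyond the scatter), the only single-place step among the compounds shown, modest in size but beyond the scatter. This position therefore responds to a change of group even when the count of heavy atoms stays level: both groups count 5 heavy atoms and 1 hydrogen-bond donor, while the entering group counts 2 hydrogen-bond acceptors against 1. Nothing at hand bears on why the number moves, and the step stands as an observation on this one pair.

Open, as far as these compounds go, is which part of the change carries the step, a question that acetamido or methanesulfonamidomethyl on the same aromatic carbon would help to separate, since each would pair one part of the entering group with one part of the leaving group. Among these compounds, also open is whether the step holds with the cyclic amine of compound 2 in place of the one in compound 3, and how a carboxylic acid or a primary amine on this aromatic carbon would read in this assay.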